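The source may hold more compounds than are shown below. What is called first, only, known or untested is meant among the compounds shown, and "the series" means these compounds.

Of the compounds shown here, three built on a shared core have been measured in a functional assay on CCRF-CEM cells (Homo sapiens) for antiproliferative activity, read by MTT assay, with a stated time of 72 h, tested at 200 uM; on this read-out lower numbers stand for a stronger effect and higher numbers for a weaker effect at the one concentration tested. Compound 1 `COC(C(=O)OC(C)Cn1cnc2c1c(=O)n(C)c(=O)n2C)c1cccc2ccccc12` gives 34.6%, the largest of the three numbers recorded, though compound 2 cannot be set apart from it. Compound 2 `Cc1ccc(C(=O)CC(=O)OC(C)Cn2cnc3c2c(=O)n(C)c(=O)n3C)cc1` gives 31.6%, a number within the scatter of compound 1. Compound 3 `CC(Cn1cnc2c1c(=O)n(C)c(=O)n2C)OCc1cn(CCCn2nc3c(Br)c(Br)c(Br)c(Br)c3n2)nn1` gives 0%, a number beyond the scatter below compound 1. Among the compounds with values here, no step between measured compounds that differ in a single place is available to guide the next change. Compound 4 `COC(C(=O)OC(C)Cn1cnc2c1c(=O)n(C)c(=O)n2C)c1ccc(C(C)(C)C)cc1` differs from compound 1 by 4-(tert-butyl)phenyl in place of naphthalen-1-yl on a saturated chain carbon bound to a carbonyl carbon and an oxygen on a saturated carbon. Within the data shown here, no measured step bears on this change; the step of a number 0.4 percentage points higher from compound 1 to compound 4 (within the scatter) is expected to be small, of no clear direction, and most likely within the scatter. Compound 4 is therefore estimated to give 35%, with a range from 15% to 60%.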

Compound 4, a percentage reported as activity, at one concentration (the size of the read-out at that concentration, not a potency): 0%
Compound 4: middle estimate off by 35 percentage points, on the high side; measured number outside the range, below it.
By their numbers in this assay, from the lowest: compounds 3 and 4 (each within the scatter of the next); then compounds 2 and 1 (each within the scatter of the next).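

In this assay the group on a saturated chain carbon bound to a carbonyl carbon and an oxygen on a saturated carbon proves decisive: putting 4-(tert-butyl)phenyl in place of naphthalen-1-yl gives a large step of a number 34.6 percentage points lower from compound 1 to compound 4 (beyond the scatter) even though the heavy-atom count stays the same and one aromatic ring replaces two. Nothing available accounts for this step. From the compounds shown here alone, whether a plain phenyl or a 4-methoxyphenyl on this carbon would behave like compound 1 or like compound 4 stays open, as does whether the step persists with a hydroxyl in place of the methoxy group.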